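The source may report more compounds than this note shows. Statements on the series, on what has been measured and on what is new or still open speak of the compounds shown alone.

Compound 3 `COc1cc(-c2cc(C(=O)O)c3ccccc3n2)ccc1OCC(=O)NCc1ccccc1` is the lowest of the three numbers in a physicochemical assay for lipophilicity, using the shake flask method, in phosphate buffer, measured as octanol-water partition, at pH 7.4; a lower number here means a more polar compound, a higher number a more lipophilic compound; compound 3 gives 0.4. Its nearest neighbour is compound 1 `COc1cc(-c2cc(C(=O)O)c3ccccc3n2)ccc1OCC(=O)Nc1ccccc1`, which in this assay gives 0.7, a step that is within the scatter (a number 0.30 log units lower from compound 1 to compound 3 (within the scatter)). Furthest off is compound 2 `COc1cc(-c2cc(C(=O)O)c3ccccc3n2)ccc1OCC(=O)Nc1ccc(Cl)cc1`, which in this assay gives 1.5, so that a number 1.10 log units lower from compound 2 to compound 3 (beyond the scatter). Among the measured steps, a number 0.80 log units higher from compound 1 to compound 2 (beyond the scatter), whereas a number 0.30 log units lower from compound 1 to compound 3 (within the scatter).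

Compound 4 `CCCCCCNC(=O)COc1ccc(-c2cc(C(=O)O)c3ccccc3n2)cc1OC` differs from compound 3 in one place: pentyl in place of phenyl on a saturated chain carbon bound to an amide-type nitrogen. Going by the values given here, no measured pair shows a ring swapped for an open chain on this amide side, so the measured steps give no direct reading of it; the chloro step from compound 1 to compound 2 only shows that an added carbon-rich group can lift this assay by a modest amount. A modest rise is therefore expected, a number 0.50 log units higher from compound 3 to compound 4 (beyond the scatter). Compound 4 is expected to give 0.9 in this assay, within a range from 0.4 to 1.5.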

Compound 4, distribution coefficient: 1
For compound 4 the middle estimate is 0.10 log units below the measured one; the measured number falls inside the stated range.
By their numbers in this assay, from the lowest: compounds 3, 1 and 4 (each within the scatter of the next, the first and the last beyond it); then compound 2.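

In this assay an open chain now stands on the amide-type nitrogen, and pentyl in place of phenyl on the saturated chain carbon gives a step beyond the scatter (a number 0.60 log units higher from compound 3 to compound 4 (beyond the scatter)), so this position responds to losing the ring of the benzyl group. Taken directly on the amide-type nitrogen, hexyl cannot be told apart from phenyl (a number 0.30 log units higher from compound 1 to compound 4 (within the scatter)), but it remains clearly separate from 4-chlorophenyl (a number 0.50 log units lower from compound 2 to compound 4 (beyond the scatter)). No measurement at hand explains these steps.

The compounds shown leave open whether a longer chain or a branched chain on this nitrogen would follow the same course. They also leave open how a hexyl chain ending in an amine or a hydroxyl group would compare with hexyl itself.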